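Removing the benzyloxy group from the most active anilino compound

The source may report more compounds than this note shows. Statements on the series, on what has been measured and on what is new or still open speak of the compounds shown alone.

In an assay on mitochondria from L6 cells (Rattus norvegicus) for activation, with a stated time of 90 min (on this read-out higher numbers stand for an effect only at larger amounts of compound and lower numbers for an effect already at smaller amounts), three compounds sharing one core have been run. Compound 1 `Oc1nc2nonc2nc1Nc1ccccc1F` gives 12500 nM. Compound 2 `COc1cccc(Nc2nc3nonc3nc2O)c1` gives 75400 nM. Compound 3 `Oc1nc2nonc2nc1Nc1ccc(OCc2ccccc2)cc1` gives 2400 nM, the lowest of the three numbers; the nearest to it is the number of compound 1, and the furthest is that of compound 2, and both gaps lie beyond the usual scatter.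

Compound 4 `Oc1nc2nonc2nc1Nc1ccccc1` has not yet been measured in this assay. It differs from compound 3 in one place: hydrogen in place of benzyloxy on an aromatic carbon. The change thus takes away the benzyloxy group on the aromatic carbon para to the large group and leaves only a hydrogen there.

For the measured compounds named here, no pair among the measured compounds differs in a single place, so nothing is known directly about the size of such a step. Since compound 3 stands apart from compound 1 and compound 2 in this assay, and compound 4 would carry the plainest of the four aryl groups, the estimate is that the step of a 6.3-fold higher number from compound 3 to compound 4 (0.80 log units; beyond the scatter) goes upward, beyond the scatter. Compound 4 is therefore expected to give about 15000 nM in this assay, within a range from 4000 nM to 60000 nM.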

Compound 4, half-maximal effective concentration: 66700 nM
For compound 4 the middle estimate is 4.4-fold (0.65 log units) below the measured one, and the stated range ends below it.
By their numbers in this assay, from the lowest: compound 3; then compound 1; then compounds 4 and 2 (each within the scatter of the next).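

With compound 4 as the reference, the benzyloxy group on the aromatic carbon para to a large group can now be given a size in this assay: replacing it with hydrogen gives a 28-fold higher number from compound 3 to compound 4 (1.44 log units; beyond the scatter) and is the largest of the three steps. Replacing fluoro on an aromatic carbon with hydrogen gives a 5.3-fold higher number from compound 1 to compound 4 (0.73 log units; beyond the scatter) and runs in the same direction, but as a modest step. Replacing methoxy on an aromatic carbon with hydrogen gives a 1.1-fold lower number from compound 2 to compound 4 (0.05 log units; within the scatter) and leaves the two compounds indistinguishable, so among these three groups, a hydrogen in their place does not carry the same consequence for each. Nothing given here accounts for the difference between these steps.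

The compounds shown leave open whether the large step depends on the whole benzyloxy group, which a phenoxy or benzyl group on that same aromatic carbon could help to separate into the outer ring and its oxygen link. They also leave open how an amine or a carboxylic acid in that place would read out.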